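The source may hold more compounds than are shown below. What is called first, only, known or untested is meant among the compounds shown, and "the series" means these compounds.

Measured compounds:
- compound 1 `C#CCN1CCC(OC(=O)Nc2ccc(C(C)C)cc2)CC1`: 178 nM
- compound 2 `C#CCN1CCCC(OC(=O)Nc2ccc(C(C)C)cc2)C1`: 71800 nM
- compound 3 `CC(C)c1ccc(NC(=O)OC2CCN(Cc3ccccc3)CC2)cc1`: > 100000 nM

All three were tested in an assay on BTI-TN-5B1-4 cells for inhibition of Amine oxidase [flavin-containing] B (Homo sapiens), read by fluorescence and Amplex Red, using microsomes, with a stated time of 15 min; on this read-out lower numbers stand for stronger inhibition and higher numbers for weaker inhibition. Compound 1 gives the lowest number of the three, 178 nM. Compound 2 is built from the same atoms as compound 1, joined differently; how the two cores differ is not broken down here. In this assay compound 2 gives 71800 nM, a far higher number than compound 1. For compound 3 the assay reports only a limit, > 100000 nM, and not a number.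

The change from compound 1 to compound 3 is phenyl in place of ethynyl on a saturated chain carbon bound to an amine nitrogen in a ring. Its effect was an at least 560-fold higher number from compound 1 to compound 3 (2.74 log units; beyond the scatter), reaching (the limit of > 100000 nM in this assay, at which 1 of the 3 values shown sits).

Compound 4 `CC(C)c1ccc(NC(=O)OC2CCCN(Cc3ccccc3)C2)cc1` is not yet measured. It stands to compound 2 exactly as compound 3 stands to compound 1: the change is phenyl in place of ethynyl on a saturated chain carbon bound to an amine nitrogen in a ring, the same change on a different core. Since compound 2 already gives the high number 71800 nM, a step in this assay of about a 5.6-fold higher number from compound 2 to compound 4 (0.75 log units; beyond the scatter) is expected. Such a step would be expected to carry compound 4 past the limit of the assay. Compound 4 is therefore estimated at 400000 nM, most likely between 100000 nM and 3000000 nM, and most probably reported only as a limit.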

Compound 4, half-maximal inhibitory concentration: 29300 nM
For compound 4 the middle estimate is 14-fold (1.14 log units) above the measured one; the whole stated range lies above it.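

On the core of compound 2, putting phenyl in place of ethynyl (propargyl becoming benzyl) gives a 2.5-fold lower number from compound 2 to compound 4 (0.39 log units; beyond the scatter) in this assay. Set beside the same change on the core of compound 1, this result shows that the change does not carry over from one core to the other, in either direction or size: the same change on two cores in this assay, an at least 560-fold higher number (2.74 log units; beyond the scatter) from compound 1 to compound 3 and a 2.5-fold lower number (0.39 log units; beyond the scatter) from compound 2 to compound 4, at least 1300-fold (3.13 log units) apart, beyond the scatter of two such steps. It does not show why the two cores respond differently, and two pairs of compounds are too few to give a rule for any other core.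

The compounds shown leave open how other groups in place of ethynyl would behave on these two cores, for example a nitrile or a longer chain such as butyl. They also leave open whether a phenyl carrying a fluorine atom or a methoxy group would follow the step seen on the core of compound 1 or the one seen on the core of compound 2.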